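One side chain changed on compound 3

This account rests on a few compounds, and the source may have more. Where it says the series, first, only, none or still open, it means among the compounds named here.

In a functional assay on RAW264.7 cells (Mus musculus), read by Griess assay, with a stated time of 24 h (a lower number here means a stronger inhibitor, a higher number a weaker inhibitor), compound 3 (`C/C=C(\C)C(=O)O[C@@H]1[C@H](O)[C@@H](OC(=O)C(C)CC)[C@@H](OC(=O)/C(=C/C)CO)[C@H](O)[C@H]1OC(=O)/C(=C/C)CO`) gives 7100 nM and so holds the lowest number of the three measured compounds, which makes it the strongest inhibitor among them. Compound 2 (`C/C=C(\CO)C(=O)O[C@H]1[C@H](OC(=O)C(C)CC)[C@H](O)[C@@H](OC(=O)C(C)CC)[C@@H](O)[C@@H]1OC(=O)/C(=C/C)CO`) stands at 62900 nM and compound 1 (`C/C=C(\C)C(=O)O[C@@H]1[C@@H](O)[C@@H](OC(=O)C(C)CC)[C@H](OC(=O)/C(=C/C)CO)[C@@H](OC(=O)/C(=C/C)CO)[C@@H]1O`) at 124000 nM on the same scale, and both are clearly weaker than compound 3.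

The next compound to consider is compound 4 (`C/C=C(\CO)C(=O)O[C@@H]1[C@@H](O)[C@H](OC(=O)/C(=C/C)CO)[C@H](OC(=O)C(C)CC)[C@@H](O)[C@H]1OC(=O)C(C)CC`). It differs from compound 3 by sec-butyl in place of 1-methylprop-1-en-1-yl on a carbonyl carbon. The same exchange has been measured only once, as a 2.0-fold lower number from compound 1 to compound 2 (0.29 log units; within the scatter) and that step lies within the scatter. A single step is thin evidence, and it was seen between two compounds much weaker than compound 3. Even so, it gives no ground for expecting a step beyond the scatter in this assay here, in either direction. The expected step is a 1.0-fold lower number from compound 3 to compound 4 (0.01 log units; within the scatter) by this estimate, which amounts to little or no change. The three measured numbers lie far apart, so the range has to stay wide. Compound 4 is expected to read 7000 nM with an estimated range from 2500 nM to 25000 nM as its likely span.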

Compound 4, half-maximal inhibitory concentration: 95600 nM
Estimate against measurement, compound 4: 14-fold (1.14 log units) below; measured number above the stated range.
By their numbers in this assay, from the lowest: compound 3; then compounds 2, 4 and 1 (each within the scatter of the next).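

Exchanging 1-methylprop-1-en-1-yl for sec-butyl on a carbonyl carbon is far from a silent move in this assay: on the core of compound 3 it gives a 13-fold higher number from compound 3 to compound 4 (1.13 log units; beyond the scatter). The two groups have the same heavy-atom count and differ in the double bond that leaves with 1-methylprop-1-en-1-yl, so a small edit to one ester side chain is enough to lose most of the inhibition that sets compound 3 apart. The earlier step suggested that this position tolerates the exchange, but that reading does not carry over from one core to the other, so the effect of this change depends on the core that carries it: the same change on two cores in this assay, a 2.0-fold lower number (0.29 log units; within the scatter) from compound 1 to compound 2 and a 13-fold higher number (1.13 log units; beyond the scatter) from compound 3 to compound 4, 27-fold (1.42 log units) apart, beyond the scatter of two such steps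

The compounds shown do not reveal which feature of the two cores produces this difference, or whether the loss on the core of compound 3 comes from removing the double bond or from some other difference between the two side chains. Going by these compounds, it also remains open how an acetyl group, a benzoyl group or a longer chain on this carbonyl carbon would read in this assay.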